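The source may report more compounds than this note shows. Statements on the series, on what has been measured and on what is new or still open speak of the compounds shown alone.

Working notes on the series. In a functional assay on cells (Mus musculus) for cytotoxicity, read by MTT assay, with a stated time of 24 h, tested at 1 uM (on this read-out lower numbers stand for a weaker effect and higher numbers for a stronger effect at the one concentration tested), compound 3 `Oc1ccc(/C=N/Nc2nc3ccccc3s2)cc1O` gives 33%, a number within the scatter of compound 1 `COc1cc(/C=N/Nc2nc3ccccc3s2)cc(OC)c1O`, which in this assay gives 39%, and well below compound 2 `COc1cc(/C=N/N(C)c2nc3ccccc3s2)cc(OC)c1O`, which in this assay gives 107%. Within the data shown here, the one step measured so far, a number 68 percentage points higher from compound 1 to compound 2 (beyond the scatter), concerns a methyl on a nitrogen and does not bear on the change now in question: compound 4 `COc1cc(/C=N/Nc2nc3ccccc3s2)cc(O)c1O` carries methoxy in place of hydrogen on an aromatic carbon. Compounds 1 and 3 show that replacing both hydroxy groups by methoxy leaves the number within the scatter, so no step beyond the scatter is expected. For compound 4 the estimated step is a number 3 percentage points higher from compound 3 to compound 4 (within the scatter). In this assay compound 4 is expected to give 36%, ranging from 20% to 55%.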

Compound 4, a percentage reported as activity, at one concentration (the size of the read-out at that concentration, not a potency) in the Mus musculus assay: 38%
The estimate for compound 4 lay 2 percentage points below the measured number; the measured number falls inside the stated range.
By their numbers in the Mus musculus assay, from the lowest: compounds 3, 4 and 1 (each within the scatter of the next); then compound 2.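

In the Mus musculus assay compound 4 gives 38% and methoxy in place of hydrogen on an aromatic carbon, ortho to a hydroxy group, gives a number 5 percentage points higher from compound 3 to compound 4 (within the scatter) and hydrogen in place of methyl on an oxygen gives a number 1 percentage points lower from compound 1 to compound 4 (within the scatter) so neither single change on this ring moves the number beyond the scatter. In a physicochemical assay, read by spectrophotometry (on this read-out lower numbers stand for stronger inhibition and higher numbers for weaker inhibition), compound 4 gives 6800 nM as a first number there, but for compound 3 the entry is "not determined" (no result reported) so the step cannot be read.

Going by these compounds, whether an amine or a carboxylic acid at this position would also stay within the scatter remains open. No evidence at hand explains these results.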